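Hydroxycyclohexyl ether swap carried onto the urea core

The source may report more compounds than this note shows. Statements on the series, on what has been measured and on what is new or still open speak of the compounds shown alone.

Compound 1 `O=S(=O)(NCCNC(=S)Nc1cc(C(F)(F)F)cc(C(F)(F)F)c1)c1ccc(-c2ccccc2OCc2cccc(O)c2)s1` and compound 2 `O=C(NCCNS(=O)(=O)c1ccc(-c2ccccc2OCc2cccc(O)c2)s1)Nc1cc(C(F)(F)F)cc(C(F)(F)F)c1` share most of their structure, but how the two cores differ is not broken down here. In a functional assay on HeLa cells (Homo sapiens) for inhibition, read by CCK-8 assay, with a stated time of 48 h (on this read-out lower numbers stand for stronger inhibition and higher numbers for weaker inhibition), compound 1 gives 14900 nM and compound 2 gives 17300 nM; the two numbers lie within the scatter of each other. Compound 3 `O=S(=O)(NCCNC(=S)Nc1cc(C(F)(F)F)cc(C(F)(F)F)c1)c1ccc(-c2ccccc2O[C@H]2CC[C@@H](O)CC2)s1` carries the change 4-hydroxycyclohexyl in place of 3-hydroxybenzyl on an oxygen on an aromatic ring on the core of compound 1, and in this assay compound 3 gives 10900 nM, a step of a 1.4-fold lower number from compound 1 to compound 3 (0.14 log units; within the scatter). Compound 4 `O=C(NCCNS(=O)(=O)c1ccc(-c2ccccc2O[C@H]2CC[C@@H](O)CC2)s1)Nc1cc(C(F)(F)F)cc(C(F)(F)F)c1` carries the same change on the core of compound 2, namely (4-hydroxycyclohexyl in place of 3-hydroxybenzyl on an oxygen on an aromatic ring). The step from compound 2 to compound 4 is expected to match the earlier one, about a 1.4-fold lower number from compound 2 to compound 4 (0.14 log units; within the scatter), because the change from compound 1 to compound 3 gave a 1.4-fold lower number from compound 1 to compound 3 (0.14 log units; within the scatter). Compound 4 is estimated at 12500 nM in this assay, expected between 6000 nM and 26000 nM.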

Compound 4, half-maximal inhibitory concentration: 14100 nM
Beside the measured number, compound 4's estimate is 1.1-fold (0.05 log units) below it; the measured number falls inside the stated range.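

In this assay, 4-hydroxycyclohexyl in place of 3-hydroxybenzyl on the oxygen gives a 1.2-fold lower number from compound 2 to compound 4 (0.09 log units; within the scatter). The change reads alike on both cores: the same change on two cores in this assay, a 1.4-fold lower number (0.14 log units; within the scatter) from compound 1 to compound 3 and a 1.2-fold lower number (0.09 log units; within the scatter) from compound 2 to compound 4, 1.1-fold (0.05 log units) apart, within the scatter of two such steps

Each step lies within the scatter, so the pair shows that the swap carries over without a measurable shift on these two cores, but it shows no real gain or loss from the change, and two cores say nothing about others in the series.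

Open, going by these compounds, is whether 4-aminocyclohexyl or 4-carboxycyclohexyl on the same oxygen would move the number beyond the scatter on either core. Also open, on these data alone, is whether this agreement between cores would hold for a change that produces a step beyond the scatter.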